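Methyl in place of hydrogen on a phenyl ring

The source may report more compounds than this note shows. Statements on the series, on what has been measured and on what is new or still open speak of the compounds shown alone.

Three compounds have been measured:
- compound 1 `COc1cc2c(Oc3ccc(NC(=O)c4nn(-c5ccccc5)cc(C)c4=O)cc3F)ccnc2cc1OCCCC(=O)NO`: 1900 nM
- compound 2 `COc1cc2c(Oc3ccc(NC(=O)c4nn(-c5ccccc5)cc(C)c4=O)cc3)ccnc2cc1OCCCCCCC(=O)NO`: 420 nM
- compound 3 `COc1cc2c(Oc3ccc(NC(=O)c4nn(-c5ccccc5C)ccc4=O)cc3)ccnc2cc1OCCCCCC(=O)NO`: 3920 nM

All three share a core and were tested in a functional assay on A549 cells (Homo sapiens) for inhibition, read by MTT assay, with a stated time of 72 h; on this read-out higher numbers stand for weaker inhibition and lower numbers for stronger inhibition. Compound 2 has the lowest number of the three, so it inhibits the cells most strongly; compound 1 gives a number beyond the scatter above it, and compound 3 gives a number further still beyond the scatter. Compound 2 is therefore the strongest inhibitor among the measured compounds.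

Compound 4 `COc1cc2c(Oc3ccc(NC(=O)c4nn(-c5ccc(C)cc5)cc(C)c4=O)cc3)ccnc2cc1OCCCCCCC(=O)NO` has not yet been measured. It differs from compound 2 in one place: methyl in place of hydrogen on an aromatic carbon. The change is a methyl in place of hydrogen on an aromatic carbon of a six-membered aromatic ring of carbon only; cut one bond further out, phenyl becomes 4-methylphenyl. Among the compounds with values here, no pair of measured compounds shows this change alone, so there is no measured step to lean on. Such a small addition at a ring far from the hydroxamic acid chain is expected to give a step in this assay no larger than the scatter, in either direction. Compound 4 is therefore estimated at 500 nM, within 200 nM to 1500 nM, a step of a 1.2-fold higher number from compound 2 to compound 4 (0.08 log units; within the scatter) expected from compound 2.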

Compound 4, half-maximal inhibitory concentration: 160 nM
Compound 4: middle estimate off by 3.1-fold (0.49 log units), on the high side, and the stated range ends above it.
By their numbers in this assay, from the lowest: compound 4; then compound 2; then compound 1; then compound 3.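

Within the data shown here, the step from phenyl to 4-methylphenyl is the first single change that can be read: in this assay, methyl in place of hydrogen on an aromatic carbon, para to a large group, gives a 2.6-fold lower number from compound 2 to compound 4 (0.42 log units; beyond the scatter). This place on the ring is therefore not silent, since a methyl, which adds no hydrogen-bond donors or acceptors and no net charge, moves the number beyond the usual scatter, modestly, towards stronger inhibition of the cells. Nothing available here gives a reason for this drop.

On these data alone, it remains open whether the gain is particular to methyl or would also appear with another group at the same place, such as ethyl, methoxy, a chlorine atom, an amine or a carboxylic acid. As far as these compounds go, it is also open whether the same methyl would give a similar step in a compound with a shorter chain ending in the hydroxamic acid, since this single pair shows the change on one chain only.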